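From 2,6-dimethoxyphenyl to 2,4-dichlorophenyl at a growth assay limit

The source may report more compounds than this note shows. Statements on the series, on what has been measured and on what is new or still open speak of the compounds shown alone.

In a functional assay on HT-29 cells (Homo sapiens) for inhibition, read by sulforhodamine B assay, with a stated time of 48 h (a lower number here means a stronger inhibitor of growth, a higher number a weaker inhibitor of growth), compound 3 (`COc1cccc(OC)c1/C=N/NC(=O)Cc1csc2nc(-c3ccc(Br)cc3)cn12`) gives > 100000 nM, which is a limit and not a number. Compound 1 (`O=C(Cc1csc2nc(-c3ccc(Br)cc3)cn12)N/N=C/c1ccccc1`) gives > 100000 nM, also a limit. Both stand at the limit of > 100000 nM in this assay, at which 2 of the 3 values shown sit. Compound 2 (`O=C(Cc1csc2nc(-c3ccc(Br)cc3)cn12)N/N=C/c1ccccc1O`) alone gives a number, 19100 nM. The steps are an at least 5.2-fold lower number from compound 1 to compound 2 (0.71 log units; beyond the scatter), an at least 5.2-fold higher number from compound 2 to compound 3 (0.71 log units; beyond the scatter) and a step that the two limits leave unreadable from compound 1 to compound 3. Compound 4 (`O=C(Cc1csc2nc(-c3ccc(Br)cc3)cn12)N/N=C/c1ccc(Cl)cc1Cl`) brings (2,4-dichlorophenyl in place of 2,6-dimethoxyphenyl on a carbon with a double bond to nitrogen). The entering group carries no hydroxy, so the gain seen in an at least 5.2-fold lower number from compound 1 to compound 2 (0.71 log units; beyond the scatter) is not expected to carry over in full. A modest fall in the number is expected, and another limit remains possible. The estimated change is an at least 1.6-fold lower number from compound 3 to compound 4 (0.22 log units; that floor lies within the scatter). Compound 4 is expected at 60000 nM, within an estimated range of 20000 nM to 100000 nM.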

Compound 4, concentration for total growth inhibition: > 100000 nM
Compound 4: no number, only a limit; the forecaster's own chance of this, stated with the estimate: 45%; at least 1.6-fold (0.22 log units) between middle value and limit.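

In this assay compound 4 gives > 100000 nM, which is a limit and not a number. With 2,4-dichlorophenyl in place of 2-hydroxyphenyl there is an at least 5.2-fold higher number from compound 2 to compound 4 (0.71 log units; beyond the scatter), so at this position a ring with two chlorine atoms, like phenyl and 2,6-dimethoxyphenyl, does not match the hydroxy compound. The steps to compound 4 from compound 1 and compound 3 cannot be read: the limit of > 100000 nM in this assay, at which 3 of the 4 values shown sit.

As far as these compounds go, it remains open whether the hydroxy is unique here. An amine or a carboxylic acid in its place might also bring a number within the range of this assay.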